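This account rests on a few compounds, and the source may have more. Where it says the series, first, only, none or still open, it means among the compounds named here.

Compound 1 `CN(C)CCCNc1n[n+]([O-])c2ccccc2[n+]1[O-]` gives 38000000 nM in a physicochemical assay for solubility, in the presence of a further agent that is not named here; a higher number here means a more soluble compound, a lower number a less soluble compound.
Compound 2 `[O-][n+]1nc(NCCN2CCCCC2)[n+]([O-])c2ccccc21` gives only a limit in this assay, namely > 49000000 nM.

Compound 2 therefore stands at the limit of > 49000000 nM in this assay, at which 1 of the 2 values shown sits, and its true solubility is known only as that limit, not as a number. Among the compounds with values here, the single measured step, an at least 1.2-fold higher number from compound 1 to compound 2 (0.11 log units; that floor lies within the scatter), concerns the amine at the chain end and says nothing about the aromatic ring. Compound 3 `CC(C)c1ccc2c(c1)[n+]([O-])c(NCCN1CCCCC1)n[n+]2[O-]` differs from compound 2 by isopropyl in place of hydrogen on an aromatic carbon. Within the data shown here, no measured step bears on a change at that place, so neither size nor direction of the step in this assay can be read from the data so far. The estimate for compound 3 is accordingly broad. Compound 3 is expected at 25000000 nM. The lower end for compound 3 is estimated at 4000000 nM. The upper end for compound 3 is estimated at 60000000 nM. The step of an at least 1.9-fold lower number from compound 2 to compound 3 (0.29 log units; that floor lies within the scatter) is thus expected to be small and may again end at the limit.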

Compound 3, solubility: 18000000 nM
The estimate for compound 3 lay 1.4-fold (0.14 log units) above the measured number; the range from low to high includes it.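

In this assay, isopropyl in place of hydrogen on an aromatic carbon, meta to a fused ring and para to a fused ring, gives an at least 2.7-fold lower number from compound 2 to compound 3 (0.43 log units; beyond the scatter). Within the data shown here, this is the only measured step at this place, and it fixes the direction of the change there, with a floor beyond the scatter. The full size of the step stays unknown, as compound 2 is given only as a limit and not as a number: the limit of > 49000000 nM in this assay, at which 1 of the 3 values shown sits.

A single group at a single place leaves open whether the lower number is specific to isopropyl or extends to other groups on this aromatic carbon, such as methyl, methoxy or a carboxylic acid. Also open, as far as these compounds go, is whether the step would carry over to the (dimethylamino)methyl chain end of compound 1.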